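This account rests on a few compounds, and the source may have more. Where it says the series, first, only, none or still open, it means among the compounds named here.

Working notes on the series in a functional assay on the whole organism (Abdomen, strain Swiss) for inhibition, with Mus musculus as the target, with stated times of 30 min, 10 min and 5 min, at a dose of 20 mg/kg by the oral route; a higher number here means a stronger effect of the compound at the dose given, a lower number a weaker effect.

Of the compounds shown here, three carry numbers so far. Compound 1 `C=Cc1c(C)nn(CCCN2CCCN(c3ccc(C)cc3)CC2)c(=O)c1N` gives 10% and compound 2 `CC(=O)c1cccn1CCCN1CCN(c2ccc(F)cc2)CC1` gives 16%; compound 3 `CC(=O)c1cccn1CCCN1CCN(c2cccc(Cl)c2)CC1` gives 41% and stands highest of the three, beyond the scatter of both compound 2 and compound 1. Among the measured compounds shown here, the single one-place step measured so far, a number 25 percentage points higher from compound 2 to compound 3 (beyond the scatter), came with 3-chlorophenyl in place of 4-fluorophenyl on the amine nitrogen in the ring, so the substituent on that phenyl ring has moved the read-out once already.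

Compound 4 `COc1cccc(N2CCN(CCCn3cccc3C(C)=O)CC2)c1` differs from compound 3 by methoxy in place of chloro on an aromatic carbon. For the measured compounds named here, no measured step exchanges one substituent for another at the same position on that ring, so the step from compound 2 to compound 3 bears on it only loosely, as a sign that this phenyl ring is sensitive. Going by the values given here, with no closer precedent, a modest loss from compound 3 is expected but a flat result is also plausible; compound 4 is estimated at 30%, within 10% to 50%, meaning an expected step of a number 11 percentage points lower from compound 3 to compound 4 (beyond the scatter).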

Compound 4, a percentage reported as inhibition, in the whole organism at one dose (the size of the read-out at that dose, not a potency): 26%
For compound 4 the middle estimate is 4 percentage points above the measured one; low and high end bracket the measured number.
By their numbers in this assay, from the lowest: compounds 1, 2 and 4 (each within the scatter of the next, the first and the last beyond it); then compound 3.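

Methoxy in place of chloro on an aromatic carbon, meta to a large group, gives a number 15 percentage points lower from compound 3 to compound 4 (beyond the scatter) in this assay; this is the first exchange of one substituent for another at a single place on this phenyl ring, and it shows that the read-out depends on which group sits there. With 3-methoxyphenyl in place of 4-fluorophenyl the result is a number 10 percentage points higher from compound 2 to compound 4 (within the scatter), whereas 3-chlorophenyl gave a number 25 percentage points higher from compound 2 to compound 3 (beyond the scatter), so the separation from compound 2 goes with the chloro compound and not with every group at this place. No measured property of these groups bears on the result.

As far as these compounds go, it remains open whether bromo or trifluoromethyl on that aromatic carbon would match chloro or methoxy. A plain hydrogen there would show how much of the read-out either substituent contributes.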